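Biaryl lactones against a reductase: one ring swap ahead

The source may hold more compounds than are shown below. What is called first, only, known or untested is meant among the compounds shown, and "the series" means these compounds.

Compound 1, `O=C1C[C@H](O)CC(CCc2ccccc2-c2ccccc2)O1`, gives 44000 nM in an assay for inhibition of 3-hydroxy-3-methylglutaryl-coenzyme A reductase (Rattus norvegicus); a lower number here means a stronger inhibitor, a higher number a weaker inhibitor.
Compound 2, `O=C1C[C@H](O)C[C@@H](/C=C/c2ccccc2-c2ccccc2)O1`, gives 3000 nM in this assay.
Compound 3, `COc1ccc(-c2cc(Cl)cc(Cl)c2/C=C/[C@@H]2C[C@@H](O)CC(=O)O2)cc1`, gives 470 nM in this assay.

Of the three numbers, compound 3 has the lowest. Compound 2 is nearest to it, yet the gap between the two lies beyond the scatter; compound 1 stands furthest away, also beyond the scatter. No pair among these three differs in a single place, so none of the gaps can be pinned to one structural change.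

Compound 4, `Cc1cc(F)ccc1-c1cc(Cl)cc(Cl)c1/C=C/[C@@H]1C[C@@H](O)CC(=O)O1`, has not yet been measured in this assay. It departs from compound 3 by one change: 4-fluoro-2-methylphenyl in place of 4-methoxyphenyl on an aromatic carbon. Both the leaving and the entering group are of the same size and carry no charge; what changes is the loss of the one hydrogen-bond acceptor and the entry of a fluorine and a methyl on the ring that sits ortho to a large group and meta to two chloro groups.

Within the data shown here, with no comparable step among the measured compounds, the expectation for compound 4 is a step of no more than modest size in this assay, in either direction, described as a 1.5-fold lower number from compound 3 to compound 4 (0.17 log units; within the scatter). Compound 4 is thus estimated at 320 nM, within a range from 80 nM to 1300 nM.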

Compound 4, half-maximal inhibitory concentration: 36 nM
The estimate for compound 4 lay 8.9-fold (0.95 log units) above the measured number; measured number outside the range, below it.
By their numbers in this assay, from the lowest: compound 4; then compound 3; then compound 2; then compound 1.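

Among these compounds, the exchange of 4-methoxyphenyl for 4-fluoro-2-methylphenyl gives a 13-fold lower number from compound 3 to compound 4 (1.12 log units; beyond the scatter) in this assay and is the first change at a single place that can be read here. It shows that the group on this aromatic carbon, ortho to a large group and meta to two chloro groups, strongly affects the number, even though the two groups have the same heavy-atom count and neither carries a charge. Nothing available explains the size of this step.

The change removes the methoxy and adds the fluorine and the methyl together, so the compounds shown do not tell which of these accounts for the step. From the compounds shown here alone, how this position would respond to an amine or a carboxylic acid on the ring, or to a trifluoromethyl in place of the fluorine, also remains open.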